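Nitro in place of cyano on the aryl ring

The source may report more compounds than this note shows. Statements on the series, on what has been measured and on what is new or still open speak of the compounds shown alone.

Measured so far:
compound 1 `CC1=C(/C=C/C(=O)/C=C/c2ccccc2)C(C)(C)CCC1`: 20400 nM
compound 2 `CC1=C(/C=C/C(=O)/C=C/c2ccc(C#N)cc2)C(C)(C)CCC1`: 23400 nM

In a functional assay on IMR-32 cells (Homo sapiens) for cytotoxicity, read by sulforhodamine B assay, with a stated time of 48 h (on this read-out lower numbers stand for stronger inhibition and higher numbers for weaker inhibition), compound 1 gives 20400 nM. In the same assay compound 2 gives 23400 nM, the highest of the two numbers, with compound 1 nearest to it. Going by the values given here, the only measured step, a 1.1-fold higher number from compound 1 to compound 2 (0.06 log units; within the scatter), is a substituent change on the same aromatic carbon and lies within the scatter.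

Compound 3 `CC1=C(/C=C/C(=O)/C=C/c2ccc([N+](=O)[O-])cc2)C(C)(C)CCC1` differs from compound 2 by nitro in place of cyano on an aromatic carbon. Among the compounds with values here, the step from compound 1 to compound 2 bears on it, since it is the only change at this position that has been measured, and it was too small to separate from the scatter. Within the data shown here, no other step is available. On that basis no change beyond the scatter is expected; the estimated step of a 1.2-fold lower number from compound 2 to compound 3 (0.07 log units; within the scatter) is small. Compound 3 is therefore expected to give about 20000 nM, with a range from 8000 nM to 50000 nM.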

Compound 3, half-maximal inhibitory concentration: 3200 nM
The estimate for compound 3 lay 6.3-fold (0.80 log units) above the measured number; measured number below the stated range.
By their numbers in this assay, from the lowest: compound 3; then compounds 1 and 2 (each within the scatter of the next).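

In this assay the aromatic carbon para to a large group proves able to move the number, but only with some groups: nitro in place of cyano gives a 7.3-fold lower number from compound 2 to compound 3 (0.86 log units; beyond the scatter), and nitro in place of hydrogen gives a 6.4-fold lower number from compound 1 to compound 3 (0.80 log units; beyond the scatter). The earlier change at this carbon, cyano in place of hydrogen, stayed within the scatter, so compound 1 and compound 2 alone gave no sign of this sensitivity, and compound 3 is the only one of the three set apart from the others. No measurement at hand bears on why nitro and cyano differ here.

On these data alone, whether an amine, a carboxylic acid or a methoxy group on this same carbon would track with nitro or with cyano remains open. Also open, as far as these compounds go, is whether nitro on another carbon of this ring would give a comparable number.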